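This account rests on a few compounds, and the source may have more. Where it says the series, first, only, none or still open, it means among the compounds named here.

Compound 1 `O=C(Nc1cccc(-c2oc3cc(-c4ccc(F)cc4)ccc3c(=O)c2O)c1)c1ccccc1F` gives 10100 nM in a functional assay on HepG2 cells (Homo sapiens) for antiproliferative activity, read by CCK-8 assay, with a stated time of 72 h; a higher number here means a weaker inhibitor, a lower number a stronger inhibitor. For the measured compounds named here, compound 2 `O=C(Nc1cccc(-c2oc3cc(-c4ccc(F)cc4)ccc3c(=O)c2O)c1)c1ccc(F)cc1F` gives 26400 nM in this assay, the higher of the two numbers measured so far. Compound 3 `Cc1cc(C(=O)Nc2cccc(-c3oc4cc(-c5ccc(F)cc5)ccc4c(=O)c3O)c2)ccc1F` differs from compound 2 in one place: 4-fluoro-3-methylphenyl in place of 2,4-difluorophenyl on a carbonyl carbon. Going by the values given here, the only measured step, a 2.6-fold higher number from compound 1 to compound 2 (0.42 log units; beyond the scatter), bears on this change in reverse, since a fluorine that entered there now leaves, while a methyl enters with no measured precedent. A modest move toward a lower number is therefore expected, though a result within the usual scatter would not surprise. Compound 3 is estimated at 15000 nM, between 6000 nM and 40000 nM, a step of a 1.8-fold lower number from compound 2 to compound 3 (0.25 log units; within the scatter).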

Compound 3, half-maximal inhibitory concentration: 9540 nM
Beside the measured number, compound 3's estimate is 1.6-fold (0.20 log units) above it; measured number inside the range.
By their numbers in this assay, from the lowest: compounds 3 and 1 (each within the scatter of the next); then compound 2.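

In this assay the change from 2,4-difluorophenyl to 4-fluoro-3-methylphenyl on the carbonyl carbon gives a 2.8-fold lower number from compound 2 to compound 3 (0.44 log units; beyond the scatter) and so shows that this position accepts a methyl with no loss against compound 2. Replacing 2-fluorophenyl with the same group gives a 1.1-fold lower number from compound 1 to compound 3 (0.02 log units; within the scatter) and leaves compound 1 and compound 3 level. Nothing shown here offers a reason for either step. Still open, as far as these compounds go, is what the methyl does without the fluorine, as in 3-methylphenyl. Also open, from the compounds shown here alone, is how an amine or a carboxylic acid on this ring would fare.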